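A few compounds are considered here, and "the series" means these few. Any claim that something is new, unique, unknown or untested is made for them only; others in the source may bear on it.

Measured compounds: compound 1 `COc1cc[nH]c1/C=C1\C(=O)Nc2ccc([N+](=O)[O-])c(N[C@H]3CC[C@H](O)CC3)c21` gives 8040 nM in a functional assay on RKO cells (Homo sapiens) for antiproliferative activity, read by MTT assay, with a stated time of 5 days; on this read-out lower numbers stand for stronger inhibition and higher numbers for weaker inhibition; compound 2 `COc1cc[nH]c1/C=C1\C(=O)Nc2ccc([N+](=O)[O-])c(N3CCCC(O)C3)c21` gives 105 nM in this assay.

Going by the values given here, compound 2 stands lowest of the two numbers, with compound 1 as the only neighbour, a gap of a 77-fold lower number from compound 1 to compound 2 (1.88 log units; beyond the scatter). Compound 3 `COc1cc[nH]c1/C=C1\C(=O)Nc2ccc([N+](=O)[O-])c(N[C@H]3CC[C@H](O)C3)c21` carries a change on the shared core: (3-hydroxycyclopentyl)amino in place of 3-hydroxypiperidin-1-yl on an aromatic carbon. Among the compounds with values here, the one measured step that bears on this is the move from a secondary amine to the ring nitrogen, namely a 77-fold lower number from compound 1 to compound 2 (1.88 log units; beyond the scatter), a large change. Compound 3 returns to a secondary amine with a carbocycle, so a step back toward compound 1 is expected, roughly a 19-fold higher number from compound 2 to compound 3 (1.28 log units; beyond the scatter). Compound 3 is therefore estimated at 2000 nM, within 400 nM to 8000 nM.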

Compound 3, half-maximal inhibitory concentration: 339 nM
For compound 3 the middle estimate is 5.9-fold (0.77 log units) above the measured one, outside the stated range (below it).
By their numbers in this assay, from the lowest: compound 2; then compound 3; then compound 1.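

In this assay, keeping the amino link on the aromatic carbon and changing only the ring on it gives a 24-fold lower number from compound 1 to compound 3 (1.38 log units; beyond the scatter) and so shows that the ring itself matters here, not just the kind of nitrogen. Moving from the piperidine to the cyclopentylamino group gives only a 3.2-fold higher number from compound 2 to compound 3 (0.51 log units; beyond the scatter) and leaves compound 2 with the lowest number of the three. Nothing available explains these differences. As far as these compounds go, how a piperidin-1-yl without the hydroxyl, or a morpholin-4-yl, would behave at this position remains open.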